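Aryl swap on the shared core: cytotoxicity outlook

The source may hold more compounds than are shown below. What is called first, only, known or untested is meant among the compounds shown, and "the series" means these compounds.

Compound 1 `N#Cc1c(-c2ccccc2)c(C#N)c(=O)n(/N=C/c2cn(-c3ccccc3)nc2-c2ccccc2)c1N` carries a phenyl on an aromatic carbon of the shared core. In an ADME assay on HeLa cells (Homo sapiens) for cytotoxicity, read by MTT assay (on this read-out lower numbers stand for stronger inhibition and higher numbers for weaker inhibition), compound 1 gives > 200 ug/mL, which is a limit of the assay and not a number. Compound 2 `COc1cc(-c2c(C#N)c(N)n(/N=C/c3cn(-c4ccccc4)nc3-c3ccccc3)c(=O)c2C#N)cc(OC)c1OC` has 3,4,5-trimethoxyphenyl in place of that phenyl. In this assay compound 2 gives > 200 ug/mL, again a limit and not a number. The step that the two limits leave unreadable from compound 1 to compound 2 therefore cannot be read in size or direction. Within the data shown here, compound 2 thus stands only at a limit, and the one further value shown is a limit as well, as the limit of > 200 ug/mL in this assay, at which 2 of the 2 values shown sit, records.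

Compound 3 `N#Cc1c(-c2cccc([N+](=O)[O-])c2)c(C#N)c(=O)n(/N=C/c2cn(-c3ccccc3)nc2-c2ccccc2)c1N` differs from compound 2 by 3-nitrophenyl in place of 3,4,5-trimethoxyphenyl on an aromatic carbon. Among the measured compounds shown here, no measured step bears readably on this change; the single step between compounds 1 and 2 was left unreadable by its two limits. Nothing in the series points to a change in this assay beyond the scatter. Compound 3 is therefore expected to give 200 ug/mL in this assay, within 100 ug/mL to 400 ug/mL, which means an expected step of a number no higher from compound 2 to compound 3 (the limit leaves the size open), most likely reported once more as a limit.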

Compound 3, half-maximal inhibitory concentration: > 200 ug/mL
Compound 3 ended at the assay's limit (the forecaster's own chance of this, stated with the estimate: 80%); the middle value sits exactly at the limit.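

In this assay compound 3 gives > 200 ug/mL, a limit of the assay and not a number. The steps to compound 3 from compound 1 and compound 2 therefore cannot be read, in size or direction: the limit of > 200 ug/mL in this assay, at which 3 of the 3 values shown sit.

Left open is how phenyl, 3,4,5-trimethoxyphenyl and 3-nitrophenyl on the shared core compare in this assay, since none of the three has a readable number.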